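The source may hold more compounds than are shown below. What is called first, only, known or untested is meant among the compounds shown, and "the series" means these compounds.

Measured so far in a toxicity assay on MT2 cells (Homo sapiens) for cytotoxicity, read by XTT assay, with a stated time of 4 days; a lower number here means that less compound is tolerated, a higher number that more compound is tolerated:

Compound 1 `Cc1ccc(CCOc2ccc(-c3c(C)nc(C)c([C@H](OC(C)(C)C)C(=O)O)c3N3CCC(C)(C)CC3)cc2)cc1` gives >= 33500 nM, which is a limit of this assay and not a number.
Compound 2 `Cc1cc(CCOc2ccc(-c3c(C)nc(C)c([C@H](OC(C)(C)C)C(=O)O)c3N3CCC(C)(C)CC3)cc2)ccc1F` gives >= 33500 nM, likewise a limit.
Compound 3 `Cc1nc(C)c([C@H](OC(C)(C)C)C(=O)O)c(N2CCC(C)(C)CC2)c1-c1ccc(OCCc2ccccn2)cc1` gives >= 25000 nM, also a limit.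

Compound 2 thus stands only at a limit, and the two further values shown are limits as well, so its place among them cannot be read as a number. Two of the three values sit at the limit of >= 33500 nM in this assay, at which 2 of the 3 values shown sit, and one at the limit of >= 25000 nM in this assay, at which 1 of the 3 values shown sits.

Compound 4 `Cc1nc(C)c([C@H](OC(C)(C)C)C(=O)O)c(N2CCC(C)(C)CC2)c1-c1ccc(OCCc2ccncc2)cc1` has not yet been measured. It differs from compound 2 in one place: pyridin-4-yl in place of 4-fluoro-3-methylphenyl on a saturated chain carbon, two bonds along the chain from an oxygen on an aromatic ring. The measured steps that touch this part of the molecule are a step that the two limits leave unreadable from compound 1 to compound 2, a step that the two limits leave unreadable from compound 1 to compound 3 and a step that the two limits leave unreadable from compound 2 to compound 3; none of them yields a readable size, since every value involved is a limit. Compound 3 carries pyridin-2-yl at the same place and gives only a limit. Exchanges at this place have so far left all three compounds at limits, so no step beyond the scatter is expected in this assay. Compound 4 is therefore estimated at about 33500 nM, between 15000 nM and 80000 nM, and will most likely again be reported only as a limit. The step this estimate means is a number no higher from compound 2 to compound 4 (the limit leaves the size open), expected to lie within the scatter.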

Compound 4, half-maximal cytotoxic concentration: >= 25000 nM
Compound 4 was reported as a limit; the forecaster's own chance of this, stated with the estimate: 85%; the middle value lies beyond the limit too.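

In this assay compound 4 gives >= 25000 nM, which is a limit of the assay and not a number. Its steps to compound 1, compound 2 and compound 3 cannot be read. The compounds shown leave open at what concentration any of these four harms the cells, and whether exchanging this ring changes that concentration at all.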